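The source may hold more compounds than are shown below. What is called first, only, known or untested is meant among the compounds shown, and "the series" means these compounds.

Measured compounds:
Compound 1 `CC(=O)c1ccc(NC(=O)c2nc(-c3ccccc3)n(-c3ccc(S(N)(=O)=O)cc3)n2)cc1`: 53%
Compound 2 `NC(=O)c1nc(-c2ccccc2)n(-c2ccc(S(N)(=O)=O)cc2)n1`: 43%

Going by the values given here, in a functional assay on the whole organism for inhibition, with Rattus norvegicus as the target, read by paw edema, with stated times of 30 min and 1 h, at a dose of 0.28 mmol/kg by the oral route (on this read-out higher numbers stand for more inhibition at the one dose given (going by the name of the read-out) and lower numbers for less inhibition), compound 2 stands as the lower of the two numbers, with compound 1 as its nearest neighbour; the only measured step, a number 10 percentage points lower from compound 1 to compound 2 (within the scatter), lies within the scatter, so the two compounds cannot be placed in any order on this read-out.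

Compound 3 `NS(=O)(=O)c1ccc(-n2nc(C(=O)NC3CCCCC3)nc2-c2ccccc2)cc1` differs from compound 2 in one place: cyclohexyl in place of hydrogen on an amide-type nitrogen. The step from compound 1 to compound 2 is the only one that bears on this change, as it also exchanges the substituent on an amide-type nitrogen, and it was within the scatter. No other information on substitution at that nitrogen is available. The step of a number 5 percentage points higher from compound 2 to compound 3 (within the scatter) in this assay is therefore expected to be none beyond the scatter. For compound 3 the estimate in this assay is 48%, with a range from 30% to 66%.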

Compound 3, a percentage reported as inhibition, in the whole organism at one dose (the size of the read-out at that dose, not a potency): 20%
The estimate for compound 3 lay 28 percentage points above the measured number; the whole stated range lies above it.
By their numbers in this assay, from the lowest: compound 3; then compounds 2 and 1 (each within the scatter of the next).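

At the amide-type nitrogen, the substituent can change the read-out in this assay: cyclohexyl in place of hydrogen gives a number 23 percentage points lower from compound 2 to compound 3 (beyond the scatter), whereas the earlier pair at this nitrogen stayed within the scatter. The change from 4-acetylphenyl to cyclohexyl gives a number 33 percentage points lower from compound 1 to compound 3 (beyond the scatter), so these two ring-bearing substituents are not interchangeable here, and substitution at this nitrogen is not neutral as the first pair alone might have suggested. Nothing available accounts for the lower number of compound 3.

Still open, from the compounds shown here alone, is whether that lower number is specific to cyclohexyl or extends to other carbon-only groups on this nitrogen, such as methyl, a longer alkyl chain or unsubstituted phenyl. Also open, going by these compounds, is whether the acetyl of compound 1 matters, or whether an aromatic ring alone would keep the number in the range of compound 1 and compound 2.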